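The source may report more compounds than this note shows. Statements on the series, on what has been measured and on what is new or still open speak of the compounds shown alone.

Compound 1 `Cc1cc2c(c(N)nn2C)c(N2CCCCC2)n1` and compound 2 `COCCNc1nc(C)cc2c1c(N)nn2C` share one core and differ at a single position. In an assay on isolated protein for inhibition of MAP kinase-activated protein kinase 5 (Homo sapiens), read by mobility shift assay, tested at 30 uM (a lower number here means less inhibition, a higher number more inhibition at the concentration tested (going by the name of the read-out)), compound 1 gives 17%, while compound 2 gives 5%. The change from compound 2 to compound 1 is piperidin-1-yl in place of (2-methoxyethyl)amino on an aromatic carbon, and it makes a step of a number 12 percentage points higher from compound 2 to compound 1 (beyond the scatter).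

Compound 3 `COCCNc1nc(C)cc2nn(-c3ccccc3)c(N)c12` carries a different core; the difference between the core of compound 3 and the core of compound 2 is not broken down here. In this assay compound 3 gives 2%, a number within the usual scatter of compound 2 and beyond it relative to compound 1.

Compound 4 `Cc1cc2nn(-c3ccccc3)c(N)c2c(N2CCCCC2)n1` has not yet been measured. It is related to compound 3 by piperidin-1-yl in place of (2-methoxyethyl)amino on an aromatic carbon, the same change that relates compound 2 to compound 1, at a position described in the same words. Within the data shown here, the only precedent for this change in this assay is the step of a number 12 percentage points higher from compound 2 to compound 1 (beyond the scatter), which lies beyond the scatter but is modest. Resting on that single precedent, a step of about a number 12 percentage points higher from compound 3 to compound 4 (beyond the scatter) is expected, since the same change gave a number 12 percentage points higher from compound 2 to compound 1 (beyond the scatter) on the other core. Compound 4 is therefore estimated to give 14% in this assay, with a likely range from 2% to 26%. Whether the change carries across to the second core rests on one pair alone, so the estimate is held loosely.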

Compound 4, a percentage reported as inhibition, at one concentration (the size of the read-out at that concentration, not a potency): 10%
Compound 4: middle estimate off by 4 percentage points, on the high side; measured number inside the range.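

In this assay, piperidin-1-yl in place of (2-methoxyethyl)amino on the second core gives a number 8 percentage points higher from compound 3 to compound 4 (within the scatter), so this step alone does not stand clear of the usual scatter, whereas the earlier step, a number 12 percentage points higher from compound 2 to compound 1 (beyond the scatter), does. Set side by side, the two steps do not differ: the same change on two cores in this assay, a number 12 percentage points higher (beyond the scatter) from compound 2 to compound 1 and a number 8 percentage points higher (within the scatter) from compound 3 to compound 4, 4 percentage points apart, within the scatter of two such steps This shows that the two cores are compatible with one shared step size, but it does not show that the change carries across reliably, since it rests on only two pairs at a single tested concentration, says nothing about potency, and cannot separate the arrival of the ring from the loss of the hydrogen-bond donor or the ether oxygen.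

The compounds shown leave open whether other amines on this aromatic carbon, such as morpholin-4-yl, pyrrolidin-1-yl or dimethylamino, would give steps like those of piperidin-1-yl, which might help separate the ring from the other differences. They also leave open how the change behaves on a core that carries, in place of the methyl or phenyl group, something else such as an ethyl or a pyridyl group.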